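A few compounds are considered here, and "the series" means these few. Any claim that something is new, unique, unknown or untested is made for them only; others in the source may bear on it.

In an ADME assay on the whole organism (Mus musculus, strain Swiss Webster) for pharmacokinetics, read by LC-MS, at a dose of 50 mg/kg by the oral route; on this read-out higher numbers stand for higher exposure at the dose given and lower numbers for lower exposure:
- compound 1 `O=C(Nc1ccc(F)c(-c2nc3ncc(-c4cc(F)ccc4F)cc3[nH]2)c1)N1CCCC1`: 5620 ng.h/mL
- compound 2 `O=C(Nc1ccc(F)c(-c2nc3ncc(-c4ccc(F)cc4)cc3[nH]2)c1)N1CCCC1`: 10200 ng.h/mL

Compound 2 stands at 10200 ng.h/mL, level with compound 1 once the scatter is allowed for. Going by the values given here, the one measured step is a 1.8-fold higher number from compound 1 to compound 2 (0.26 log units; within the scatter). Compound 3 `O=C(Nc1ccc(F)c(-c2nc3ncc(-c4cccnc4F)cc3[nH]2)c1)N1CCCC1` carries 2-fluoropyridin-3-yl in place of 4-fluorophenyl on an aromatic carbon. Among the compounds with values here, the measured step changed the group at the same place, so it is the only guide. Within the data shown here, no measured compound has a ring with a hetero atom there, which leaves the guide a loose one. No step beyond the scatter is therefore expected in this assay, in either direction. The estimated step is a 1.5-fold lower number from compound 2 to compound 3 (0.16 log units; within the scatter). Compound 3 is expected at 7000 ng.h/mL, with an estimated range of 2500 ng.h/mL to 18000 ng.h/mL.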

Compound 3, area under the concentration-time curve: 30900 ng.h/mL
Compound 3: middle estimate off by 4.4-fold (0.64 log units), on the low side; the measured number lies above the stated range.
By their numbers in this assay, from the lowest: compounds 1 and 2 (each within the scatter of the next); then compound 3.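

In this assay the place on the aromatic carbon, two atoms from the ring nitrogen, now shows a step beyond the scatter: 2-fluoropyridin-3-yl in place of 4-fluorophenyl gives a 3.0-fold higher number from compound 2 to compound 3 (0.48 log units; beyond the scatter) and 2-fluoropyridin-3-yl in place of 2,5-difluorophenyl gives a 5.5-fold higher number from compound 1 to compound 3 (0.74 log units; beyond the scatter) on the same read-out. Going by these compounds alone, the two fluorophenyl compounds stay within the scatter of each other, so the only step of size here comes with the ring holding a hetero atom, which counts one hydrogen-bond acceptor where 4-fluorophenyl counts none. Nothing available bears on what lies behind this step.

The compounds shown do not separate the ring nitrogen from the fluorine, which an unsubstituted pyridin-3-yl would do. From the compounds shown here alone, how an amine or a methoxy group on the pyridine ring would fare at this place also remains open.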